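A few compounds are considered here, and "the series" means these few. Any claim that something is new, unique, unknown or untested is made for them only; others in the source may bear on it.

In an ADME assay on the whole organism (strain Han-Wistar) for pharmacokinetics, with Rattus norvegicus as the target, read by LC-MS, at a dose of 2 mg/kg by the oral route (on this read-out higher numbers stand for higher exposure at the dose given and lower numbers for lower exposure), compound 3 `CCc1ccc(Cl)c(C(=O)NC(=O)Nc2nc3ccc(S(=O)(=O)CCCN4CCN(C)CC4)cc3s2)c1` gives 1500 nM, the second highest of the three numbers recorded. Compound 1 `CCN(CC)CCCS(=O)(=O)c1ccc2nc(NC(=O)NC(=O)c3cc(-n4cccn4)ccc3Cl)sc2c1` gives 1600 nM in this assay, which lies within the scatter of the value for compound 3, so the two cannot be set apart. Compound 2 `CN1CCN(CCCS(=O)(=O)c2ccc3nc(NC(=O)NC(=O)c4cc(-n5cccn5)c(Cl)cc4Cl)sc3c2)CC1` gives 30 nM in this assay, a far lower exposure, well beyond the scatter. Compound 4 `CN1CCN(CCCS(=O)(=O)c2ccc3nc(NC(=O)NC(=O)c4cc5c(ccn5C)cc4Cl)sc3c2)CC1` has not been measured yet. Compared with compound 3 it carries 5-chloro-1-methyl-1H-indol-6-yl in place of 2-chloro-5-ethylphenyl on a carbonyl carbon. For the measured compounds named here, no pair of measured compounds differs by exactly this change, so the size of the step is open. The values of compound 3 and compound 2 show that exposure in this assay can shift a great deal between close relatives, although those two differ in more than one place. Compound 4 is expected to give 600 nM in this assay, within a range from 150 nM to 2500 nM. The step from compound 3 to compound 4 is estimated as a 2.5-fold lower number from compound 3 to compound 4 (0.40 log units; beyond the scatter), a moderate decrease that mainly reflects the uncertainty of an untested change.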

Compound 4, maximal plasma concentration: 300 nM
The estimate for compound 4 lay 2.0-fold (0.30 log units) above the measured number, within the range that was stated.
By their numbers in this assay, from the lowest: compound 2; then compound 4; then compounds 3 and 1 (each within the scatter of the next).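

For the compounds shown here, on the carbonyl carbon whose other neighbour is an amide-type nitrogen, replacing 2-chloro-5-ethylphenyl with 5-chloro-1-methyl-1H-indol-6-yl gives a 5.0-fold lower number from compound 3 to compound 4 (0.70 log units; beyond the scatter) in this assay, the first change here that can be read on its own. With the rest of the molecule unchanged, the group at this one place is thus enough to move oral exposure beyond the scatter, although the fall is modest. No measurement shown bears on why the number falls.

Which part of the entering group accounts for the step remains open, since the added ring and its methyl group arrive together. Also open, from the compounds shown here alone, is how a smaller group, such as methoxy in place of the ethyl group on the phenyl ring, would behave at this place.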